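The source may hold more compounds than are shown below. What is called first, only, known or untested is meant among the compounds shown, and "the series" means these compounds.

Compound 1 `CCOc1cccc(/C=N/NC(=O)c2cnccn2)c1` gives 71% in an ADME assay on J774 cells (Mus musculus) for cytotoxicity, read by MTT assay, with a stated time of 48 h, tested at 100 ug/mL; on this read-out higher numbers stand for a weaker effect at the one concentration tested and lower numbers for a stronger effect.
Compound 2 `CCOc1ccc(/C=N/NC(=O)c2cnccn2)cc1` gives 98% in this assay.
Compound 3 `O=C(N/N=C/c1cccc(O)c1)c1cnccn1` gives 100% in this assay.

Compound 1 and compound 2 share the same atoms joined differently; the difference between the two cores is not broken down here. Compound 3 differs from compound 1 by hydrogen in place of ethyl on an oxygen on an aromatic ring, and that change gave a number 29 percentage points higher from compound 1 to compound 3 (beyond the scatter). The values of compound 2 and compound 3 lie within the scatter of each other, so nothing separates them. Compound 4 `O=C(N/N=C/c1ccc(O)cc1)c1cnccn1` carries the same change relative to compound 2, namely (hydrogen in place of ethyl on an oxygen on an aromatic ring), at a place described in the same words. The step from compound 2 to compound 4 is expected to be a number 1 percentage points higher from compound 2 to compound 4 (within the scatter), smaller than the earlier step, because compound 2 already gives 98% and little room remains on this read-out. Compound 4 is therefore estimated at 99%, within a range from 90% to 108%.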

Compound 4, a percentage reported as activity, at one concentration (the size of the read-out at that concentration, not a potency): 81%
Beside the measured number, compound 4's estimate is 18 percentage points above it, and the stated range ends above it.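

Putting hydrogen in place of ethyl on the oxygen gave a number 17 percentage points lower from compound 2 to compound 4 (beyond the scatter), so in this assay this change did not carry over from one core to the other: the same change on two cores in this assay, a number 29 percentage points higher (beyond the scatter) from compound 1 to compound 3 and a number 17 percentage points lower (beyond the scatter) from compound 2 to compound 4, 46 percentage points apart, beyond the scatter of two such steps

Going from ethoxy to hydroxy therefore cannot be treated as a step of fixed size or direction in this series, since its direction reversed between these two cores. These two pairs do not show why the cores respond differently, or how the change would behave on a third core.

The compounds shown carry only ethoxy or hydroxy at this place. On these data alone, how a methoxy group, a longer chain such as butoxy, or an amine would read in this assay on either core remains open.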